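The source may report more compounds than this note shows. Statements on the series, on what has been measured and on what is new or still open speak of the compounds shown alone.

Working notes on the series. Compound 1 `CC1CCN(C2CCN(S(=O)(=O)c3ccc(-c4ccccc4F)cc3)CC2)CC1` carries a 2-fluorophenyl on the shared core. In an ADME assay on HCT-116 cells (Homo sapiens) for cytotoxicity, read by CellTiter-Glo, with a stated time of 72 h (on this read-out higher numbers stand for weaker inhibition and lower numbers for stronger inhibition), compound 1 gives > 5000 nM, which is a limit of the assay and not a number. Compound 2 `CC1CCN(C2CCN(S(=O)(=O)c3cccc(-c4ccccc4)c3)CC2)CC1` carries an unsubstituted phenyl on the shared core. In this assay compound 2 gives > 5000 nM, likewise a limit of the assay and not a number. Among the compounds with values here, compound 1 therefore stands at the limit of > 5000 nM in this assay, at which 2 of the 2 values shown sit; no numeric value exists for either measured compound, and no measured step between them can be sized.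

Compound 3 `COc1ccc(-c2ccc(S(=O)(=O)N3CCC(N4CCC(C)CC4)CC3)cc2)cc1` has not yet been tested in this assay. It differs from compound 1 by 4-methoxyphenyl in place of 2-fluorophenyl on an aromatic carbon. With both compound 1 and compound 2 at the limit, the step that the limit leaves unreadable from compound 1 to compound 3 is expected to be none beyond the scatter, since nothing in the measured pair points to a gain of cytotoxicity from a change of this kind. Compound 3 is accordingly estimated at 8000 nM, within 3000 nM to 25000 nM, and the result is most likely to be reported once more as a limit rather than a number.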

Compound 3, half-maximal inhibitory concentration: > 5000 nM
Compound 3: a limit, no number; the forecaster's own chance of this, stated with the estimate: 85%; the middle value lies beyond the limit too.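

No step can be read from compound 1 to compound 3 in this assay, since both results are limits of the assay and not numbers: the limit of > 5000 nM in this assay, at which 3 of the 3 values shown sit. The compounds shown leave open whether 2-fluorophenyl and 4-methoxyphenyl differ in their bearing on cytotoxicity, and at what concentration any of the three compounds would reach half-maximal inhibition.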